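Chain extension on compound 1: ethoxy to propoxy

A few compounds are considered here, and "the series" means these few. Any claim that something is new, unique, unknown or untested is made for them only; others in the source may bear on it.

compound 1 `CCOc1cc(-c2ccccc2)nc2ccccc12` — > 10 ug/mL
compound 2 `Oc1ccc2nc(-c3ccccc3)cc(O)c2c1` — 0.83 ug/mL

In a functional assay on L1210 (1565) cells (Mus musculus) for cytotoxicity (on this read-out lower numbers stand for an effect already at smaller amounts and higher numbers for an effect only at larger amounts of compound), compound 1 is not given as a number but as a limit, > 10 ug/mL. Compound 1 therefore stands at the limit of > 10 ug/mL in this assay, at which 1 of the 2 values shown sits. Going by the values given here, compound 2 gives 0.83 ug/mL in this assay; no step between compound 1 and compound 2 is counted here, so the two values simply stand side by side, with compound 2 effective at the smaller amount.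

Compound 3 `CCCOc1cc(-c2ccccc2)nc2ccccc12` is the unmeasured member and differs from compound 1 by methyl in place of hydrogen on a saturated chain carbon, two bonds along the chain from an oxygen on an aromatic ring. Among the compounds with values here, no measured pair shows a step of this kind, so nothing in the data fixes its size or direction. The expectation is a step within the usual scatter, and the step that the limit leaves unreadable from compound 1 to compound 3 is what this estimate means. Compound 3 is accordingly expected at about 15 ug/mL, in a range from 5 ug/mL to 50 ug/mL, with a good chance that this assay again reports only a limit.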

Compound 3, half-maximal effective concentration: > 10 ug/mL
Compound 3: only a limit was reported (the forecaster's own chance of this, stated with the estimate: 70%); the middle value does not contradict the limit.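

Compound 1 and compound 3 both stand only as limits, so no step between them can be read for the change from ethoxy to propoxy: the limit of > 10 ug/mL in this assay, at which 2 of the 3 values shown sit.

The compounds shown leave open whether this chain extension changes the effect at all, and in which direction.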